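Replacing the Side Chain of Compound 1

A few compounds are considered here, and "the series" means these few. Any claim that something is new, unique, unknown or untested is made for them only; others in the source may bear on it.

Compound 1 `Cc1c(C(N)=O)sc2nc(N/N=C/c3ccc(Br)cc3)n(Cc3ccccc3)c(=O)c12` gives 34% in a functional assay on the whole organism (strain albino) for inhibition, with Rattus norvegicus as the target, read by paw edema, in the formalin test, with a stated time of 1 h, at a dose of 10 mg/kg by the oral route; on this read-out higher numbers stand for more inhibition at the one dose given (going by the name of the read-out) and lower numbers for less inhibition. Compound 2 `Cc1c(C(N)=O)sc2nc(-n3nc(-c4ccc(Cl)cc4)cc3N)n(Cc3ccccc3)c(=O)c12` gives 30% in this assay. The value of compound 1 is the larger of the two numbers shown, yet the gap to compound 2 lies within the scatter, so the two cannot be told apart. Compound 3 `CC1=NN(c2nc3sc(C(N)=O)c(C)c3c(=O)n2Cc2ccccc2)C(=O)C1` has not been measured; it differs from compound 1 by a group of 7 heavy atoms (4 carbon, 2 nitrogen, 1 oxygen; one five-membered non-aromatic ring with 2 hetero atoms) in place of a group of 10 heavy atoms (7 carbon, 2 nitrogen, 1 bromine; one six-membered aromatic ring of carbon only), on an aromatic carbon. Among the measured compounds shown here, no measured step of this kind exists. The step of a number 6 percentage points lower from compound 1 to compound 3 (within the scatter) is expected to stay within the scatter, leaning slightly downward. Compound 3 is therefore estimated to give 28%, between 15% and 42%.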

Compound 3, a percentage reported as inhibition, in the whole organism at one dose (the size of the read-out at that dose, not a potency): 34%
Beside the measured number, compound 3's estimate is 6 percentage points below it; the measured number falls inside the stated range.
By their numbers in this assay, from the lowest: compounds 2, 1 and 3 (each within the scatter of the next).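

In this assay the exchange at this aromatic carbon gives no change at the digits printed from compound 1 to compound 3 (within the scatter), so a group with no bromine, no six-membered aromatic ring and no hydrogen-bond donor reads the same as the larger group it replaces. At this one dose, then, none of those features of compound 1 proves necessary for the reading. Nothing available explains why the reading holds across this change.

The compounds shown leave open whether a plain amine or a carboxylic acid on this carbon would keep the reading. They also leave open whether the methyl group on the five-membered ring of compound 3 matters.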